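Rat plasma stability of the diester series: compound 4 outlook

A few compounds are considered here, and "the series" means these few. Any claim that something is new, unique, unknown or untested is made for them only; others in the source may bear on it.

Measured so far:
compound 1 `CC(=O)Oc1ccccc1C(=O)O[C@H]1CO[C@H]2[C@@H]1OC[C@H]2O`: 0.055 h
compound 2 `CCCCC(=O)O[C@@H]1CO[C@H]2[C@@H]1OC[C@@H]2OC(=O)c1ccccc1OC(C)=O`: 0.0198 h
compound 3 `COc1ccccc1C(=O)O[C@@H]1CO[C@H]2[C@@H]1OC[C@@H]2OC(=O)c1ccccc1OC(C)=O`: 0.0578 h

In an ADME assay on a cell-free system (plasma, Homo sapiens) for metabolic stability, with Plasma (Rattus norvegicus) as the target, read by HPLC, at pH 7.4 (on this read-out higher numbers stand for a longer-lived compound and lower numbers for a shorter-lived compound), compound 2 stands lowest of the three numbers, below compound 1 via the step of a 2.8-fold lower number from compound 1 to compound 2 (0.44 log units; beyond the scatter) and below compound 3 via a 2.9-fold higher number from compound 2 to compound 3 (0.47 log units; beyond the scatter), both beyond the scatter. Compound 4 `CC(=O)Oc1ccccc1C(=O)O[C@H]1CO[C@H]2[C@@H]1OC[C@H]2OC(=O)c1cc(C)nc(Cl)c1` differs from compound 2 by 2-chloro-6-methylpyridin-4-yl in place of butyl on a carbonyl carbon.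

The step that bears on this is a 2.9-fold higher number from compound 2 to compound 3 (0.47 log units; beyond the scatter), where a six-membered aromatic ring also replaced butyl on the same carbonyl carbon; a 1.1-fold higher number from compound 1 to compound 3 (0.02 log units; within the scatter) adds that such a carbonyl leaves the number within the scatter of hydrogen. A modest rise from compound 2 to compound 4 is therefore expected, a 2.5-fold higher number from compound 2 to compound 4 (0.40 log units; beyond the scatter). Compound 4 is estimated at 0.05 h, in the range 0.02 h to 0.12 h.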

Compound 4, half-life: 0.0193 h
Estimate against measurement, compound 4: 2.6-fold (0.41 log units) above, and the stated range ends above it.
By their numbers in this assay, from the lowest: compounds 4 and 2 (each within the scatter of the next); then compounds 1 and 3 (each within the scatter of the next).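

In this assay an aromatic ring on this carbonyl carbon does not by itself raise the number, since a 1.0-fold lower number from compound 2 to compound 4 (0.01 log units; within the scatter) leaves 2-chloro-6-methylpyridin-4-yl within the scatter of butyl. The rise seen earlier is therefore tied to 2-methoxyphenyl rather than to aromatic rings here in general, as a 3.0-fold lower number from compound 3 to compound 4 (0.48 log units; beyond the scatter) separates the two rings. Unlike the carbonyl group of compound 3, this one also differs from hydrogen on the oxygen, with a 2.8-fold lower number from compound 1 to compound 4 (0.45 log units; beyond the scatter) as the step.

From the compounds shown here alone, whether a plain phenyl or a pyridine carrying methoxy would follow compound 3 or compound 4 remains open. Nothing available explains the difference between the two rings.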